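The compounds below may be only part of what the source reports. "The series", "measured", "known", "first", "only" and "open" are said of these compounds alone.

Of the compounds shown here, two have been measured in a functional assay on HEK293 cells for agonist activity at Neuronal acetylcholine receptor; alpha4/beta2 (Homo sapiens), read by FLIPR and calcium flux; a higher number here means that more compound is needed for the effect, a lower number that less compound is needed. Compound 1, `C/C=C\Oc1cncc(N2CCCNCC2)c1`, gives 2090 nM, the lower of the two numbers. Among the measured compounds shown here, compound 2, `Clc1cncc(N2CCNCC2)c1`, gives 22900 nM in this assay, a gap from compound 1 that lies well beyond the scatter, though the two compounds differ in more than one place and no single step can be drawn from it.

Compound 3, `NC(=O)c1cncc(N2CCCNCC2)c1`, has not yet been measured. It differs from compound 1 by a group of 3 heavy atoms (1 carbon, 1 nitrogen, 1 oxygen; no ring) in place of a group of 4 heavy atoms (3 carbon, 1 oxygen; no ring), on an aromatic carbon: a carbamoyl in place of the propenyl ether, at the same position on the shared core, with the seven-membered ring kept. For the measured compounds named here, nothing among the measured pairs isolates this exchange, so no direction can be read from the data. The step from compound 1 to compound 3 is therefore expected to stay within the scatter, or at most slightly beyond it toward a higher number, a 1.4-fold higher number from compound 1 to compound 3 (0.16 log units; within the scatter). Compound 3 is estimated to give 3000 nM in this assay, within a range from 700 nM to 13000 nM.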

Compound 3, half-maximal effective concentration: 12900 nM
Compound 3: the middle estimate sits 4.3-fold (0.63 log units) below what was measured, within the range that was stated.
By their numbers in this assay, from the lowest: compound 1; then compounds 3 and 2 (each within the scatter of the next).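

The exchange of the propenyl ether for carbamoyl, on the aromatic carbon two atoms from the ring nitrogen and with the seven-membered ring kept, gives in this assay a 6.2-fold higher number from compound 1 to compound 3 (0.79 log units; beyond the scatter). Among the compounds shown here, this is the first step that isolates a single place, and it shows that the number in this assay responds to the group held at this position. The entering carbamoyl brings a hydrogen-bond donor that the leaving group lacks, but it also differs in its atoms and size, and no measured evidence accounts for the step.

The compounds shown leave open whether a methoxy group, a longer ether chain or an amine at this position would stay near compound 1 or move toward compound 3. For the compounds shown here, they also leave open how far ring size alone shifts the number, since no pair differs only there.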